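The source may report more compounds than this note shows. Statements on the series, on what has been measured and on what is new or still open speak of the compounds shown alone.

Measured so far in a functional assay on DU-145 cells (Homo sapiens) for cytotoxicity, read by MTT assay, with a stated time of 48 h; a lower number here means a stronger inhibitor, a higher number a weaker inhibitor
- compound 1 `COc1ccc(/C=C/c2cc(OC)c(OC)c(OC)c2-c2ccc(F)c(F)c2)cc1` gives 7500 nM
- compound 2 `C=C(c1ccc(OC)cc1)c1cc(OC)c(OC)c(OC)c1-c1ccc(OC)cc1` gives 37000 nM

Compound 2 stands with the higher number of the two, beyond the scatter from compound 1. Among the compounds with values here, compound 3 `C=C(c1ccc(OC)cc1)c1cc(OC)c(OC)c(OC)c1-c1ccc(F)c(F)c1` carries 3,4-difluorophenyl in place of 4-methoxyphenyl on an aromatic carbon as its one change from compound 2. Within the data shown here, no measured step isolates this change. Compound 1 also carries 3,4-difluorophenyl and gives 7500 nM in the same read-out, though it differs from compound 3 elsewhere too, so only a moderately lower number is expected in this assay for compound 3. The estimated size is a step of a 2.5-fold lower number from compound 2 to compound 3 (0.39 log units; beyond the scatter) with wide uncertainty. The expected value for compound 3 is 15000 nM with an estimated range from 6000 nM to 38000 nM.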

Compound 3, half-maximal inhibitory concentration: 6800 nM
Estimate against measurement, compound 3: 2.2-fold (0.34 log units) above; the measured number falls inside the stated range.
By their numbers in this assay, from the lowest: compounds 3 and 1 (each within the scatter of the next); then compound 2.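

In this assay, within the data shown here, 3,4-difluorophenyl in place of 4-methoxyphenyl on this aromatic carbon gives a 5.4-fold lower number from compound 2 to compound 3 (0.74 log units; beyond the scatter), the first reading of a single change at this position. With 3,4-difluorophenyl held, 1-(4-methoxyphenyl)ethenyl in place of 2-(4-methoxyphenyl)ethenyl gives a 1.1-fold lower number from compound 1 to compound 3 (0.04 log units; within the scatter), so the two ethenyl attachments cannot be told apart in this assay. Nothing at hand explains either step.

Still open, going by these compounds, is whether 3-fluorophenyl or 4-fluorophenyl alone would match 3,4-difluorophenyl. Also open, on these data alone, is how an aminophenyl or a carboxylic acid would read on this aromatic carbon.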